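The source may hold more compounds than are shown below. What is called first, only, known or untested is meant among the compounds shown, and "the series" means these compounds.

Compound 3 `Cc1ccc(/C=C2\S/C(=N\c3nc(-c4ccc(Cl)cc4)cs3)NC2=O)cc1` gives the lowest number of the three compounds measured in a functional assay on HT-29 cells (Homo sapiens) for cytotoxicity, read by MTT assay, with a stated time of 72 h (a higher number here means a weaker inhibitor, a lower number a stronger inhibitor), at 500 nM. Compound 1 `CN(C)c1ccc(/C=C2\S/C(=N\c3csc(-c4ccc(Cl)cc4)c3)NC2=O)cc1` gives 1500 nM, and compound 2 `CCCCCC/C=C1\S/C(=N\c2csc(-c3ccc(Cl)cc3)c2)NC1=O` gives 33500 nM; compound 1 and compound 3 differ in more than one place, so their values can only be set side by side. Compound 4 `O=C1N/C(=N/c2nc(-c3ccc(Cl)cc3)cs2)S/C1=C\c1ccc(F)cc1` has not yet been measured. It differs from compound 3 by fluoro in place of methyl on an aromatic carbon. Going by the values given here, the only measured step, a 22-fold higher number from compound 1 to compound 2 (1.35 log units; beyond the scatter), exchanges an entire aromatic ring with its substituent for a hexyl chain, and it does not bear on swapping one small group for another on an aromatic carbon of a ring that otherwise stays intact. Among the compounds with values here, no measured step touches such an exchange, so the expected step of a 1.6-fold higher number from compound 3 to compound 4 (0.20 log units; within the scatter) is small and is thought to stay within the scatter of this assay. Compound 4 is therefore expected to give about 800 nM in this assay, with a range from 300 nM to 2500 nM.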

Compound 4, half-maximal inhibitory concentration: 2900 nM
Compound 4: the middle estimate sits 3.6-fold (0.56 log units) below what was measured, and the stated range ends below it.
By their numbers in this assay, from the lowest: compound 3; then compounds 1 and 4 (each within the scatter of the next); then compound 2.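

Exchanging methyl for fluoro swaps one heavy atom for one other, with no ring, hydrogen-bond donor, hydrogen-bond acceptor or net charge entering or leaving, yet in this assay the result is a 5.8-fold higher number from compound 3 to compound 4 (0.76 log units; beyond the scatter) on this aromatic carbon. The earlier step replaced a whole substituted aromatic ring with a hexyl chain, whereas this one shows that the number also responds to a single-atom exchange at a position para to a large group, with the rest of the molecule unchanged. No measurement shown here explains this shift.

On these data alone, whether methoxy or a carboxylic acid at this carbon would give a number closer to that of compound 3 or compound 4 remains open. So does whether the same exchange would have a similar effect on the core of compound 1.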